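Removing a Bromine from a Cytotoxicity Series

A few compounds are considered here, and "the series" means these few. Any claim that something is new, unique, unknown or untested is made for them only; others in the source may bear on it.

Measured so far:
compound 1 `O=C1C(=O)N(CN2CCN(c3ccnc4cc(C(F)(F)F)ccc34)CC2)c2cc(Br)ccc21`: 21800 nM
compound 2 `O=C1C(=O)N(CN2CCN(c3ccnc4cc(C(F)(F)F)ccc34)CC2)c2ccccc21`: 43900 nM
compound 3 `NC(=S)N/N=C1/C(=O)N(CN2CCN(c3ccnc4cc(Cl)ccc34)CC2)c2cc(Br)ccc21`: 13100 nM

Of the compounds shown here, three have been tested in an ADME assay on 184B5 cells (Homo sapiens) for cytotoxicity, read by sulforhodamine B assay, with a stated time of 48 h; on this read-out higher numbers stand for weaker inhibition of growth and lower numbers for stronger inhibition of growth. In this assay compound 1 gives 21800 nM, compound 2 gives 43900 nM and compound 3 gives 13100 nM. Compound 1 and compound 2 differ in one place only: hydrogen in place of bromo on an aromatic carbon. This change made a step of a 2.0-fold higher number from compound 1 to compound 2 (0.30 log units; within the scatter), so the two compounds cannot be told apart with confidence in this assay.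

Compound 3 carries a different core; the difference between the core of compound 3 and the core of compound 1 is not broken down here. Compound 3 stands at the lowest number of the three, but its gap to compound 1 is within the scatter, while its gap to compound 2 lies beyond it.

Compound 4 `NC(=S)N/N=C1/C(=O)N(CN2CCN(c3ccnc4cc(Cl)ccc34)CC2)c2ccccc21` has not yet been measured in this assay. It is made from compound 3 by hydrogen in place of bromo on an aromatic carbon. This is the same change as the one from compound 1 to compound 2, and it is seen in both pairs of compounds shown here. Because the earlier step was a 2.0-fold higher number from compound 1 to compound 2 (0.30 log units; within the scatter), the step from compound 3 to compound 4 is expected to be of similar size, estimated as a 2.0-fold higher number from compound 3 to compound 4 (0.30 log units; within the scatter). On that basis compound 4 is expected to give about 26000 nM in this assay, with an estimated range from 12000 nM to 60000 nM.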

Compound 4, concentration for 50% growth inhibition: 28800 nM
The estimate for compound 4 lay 1.1-fold (0.04 log units) below the measured number; measured number inside the range.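

In this assay, putting hydrogen in place of bromo on an aromatic carbon of the core of compound 3 gave a 2.2-fold higher number from compound 3 to compound 4 (0.34 log units; beyond the scatter), a modest step toward weaker inhibition of growth. The same change therefore moved the number in the same direction and by a closely similar amount on the two cores: the same change on two cores in this assay, a 2.0-fold higher number (0.30 log units; within the scatter) from compound 1 to compound 2 and a 2.2-fold higher number (0.34 log units; beyond the scatter) from compound 3 to compound 4, 1.1-fold (0.04 log units) apart, within the scatter of two such steps This agreement rests on just two pairs of compounds and small steps, so it shows that the change carried over between these two cores, but it does not establish a rule for other cores or explain why the number moves.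

Every compound shown carries either bromo or hydrogen at this aromatic carbon, so it remains open whether a different group there, such as a methoxy group, an amine or a carboxylic acid, would give a larger step, a smaller one or a step in the opposite direction. Going by these compounds, it also remains open whether the bromo-to-hydrogen change would give a similar step on a core bearing a longer chain in place of the piperazine-linked part, or whether the small size of the step would hold in other cell types.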